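A few compounds are considered here, and "the series" means these few. Any claim that something is new, unique, unknown or untested is made for them only; others in the source may bear on it.

Compound 1, `CCCn1c(=O)c2nc([C@H]3CC4C=CC3C4)[nH]c2n(CCC)c1=O`: 3.4 nM in an assay on cell membranes for binding affinity to adenosine receptor A1 (Cavia porcellus), read by radioligand binding; on this read-out higher numbers stand for weaker inhibition and lower numbers for stronger inhibition.
Compound 2, `CCCn1c(=O)c2nc([C@@H]3CC4CCC3C4)[nH]c2n(CCC)c1=O`: 3.8 nM in this assay.

On these two numbers compound 2 sits within the scatter of compound 1, as the step of a 1.1-fold higher number from compound 1 to compound 2 (0.05 log units; within the scatter) shows; the two bicyclic groups on the shared core give numbers that cannot be told apart.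

Compound 3, `CCCn1c(=O)c2nc(C(C)(O)CC)[nH]c2n(CCC)c1=O`, differs from compound 2 by a group of 5 heavy atoms (4 carbon, 1 oxygen; no ring) in place of a group of 7 heavy atoms (7 carbon; 2 five-membered non-aromatic rings of carbon only), on an aromatic carbon. Among the measured compounds shown here, the one measured step, a 1.1-fold higher number from compound 1 to compound 2 (0.05 log units; within the scatter), exchanges one ring pair for another of equal size and says nothing about removing the rings for an open chain bearing a hydroxyl. For the measured compounds named here, no measured step therefore bears on this change, and the direction in this assay is open. With the rings gone, a weaker result is estimated as the more likely outcome, expressed as a 7.9-fold higher number from compound 2 to compound 3 (0.90 log units; beyond the scatter). Compound 3 is thus expected to give 30 nM in this assay, within a wide range from 4 nM to 250 nM.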

Compound 3, inhibition constant: 240 nM
For compound 3 the middle estimate is 8.0-fold (0.90 log units) below the measured one; the range from low to high includes it.
By their numbers in this assay, from the lowest: compounds 1 and 2 (each within the scatter of the next); then compound 3.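

Among the compounds shown here, the earlier pair showed only that one bicyclic carbon group could replace the other on this aromatic carbon, between two ring nitrogen atoms, with no step beyond the scatter. In this assay the open 1-hydroxy-1-methylpropyl group brings a 63-fold higher number from compound 2 to compound 3 (1.80 log units; beyond the scatter) and likewise a 71-fold higher number from compound 1 to compound 3 (1.85 log units; beyond the scatter) so the position does respond to what it carries, and this open group, unlike the two bicyclic groups, goes with much weaker inhibition. No measurement at hand explains the size of this step.

This single change removes the rings and adds the hydroxyl together, so the compounds shown do not separate the two. Going by these compounds, whether a plain 1-methylpropyl group or a cyclopentyl ring would stand nearer compound 2 or compound 3 remains open.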